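The source may hold more compounds than are shown below. What is called first, only, known or untested is meant among the compounds shown, and "the series" means these compounds.

Of the compounds shown here, two have so far been tested in an ADME assay on the whole organism (muscle tissue) for activation, with Mus musculus as the target, in the rotarod test, with a stated time of 30 min; a higher number here means that more compound is needed for the effect, a lower number that less compound is needed. Compound 1 `O=C1NC(=O)N(/N=C/c2ccc(-c3ccc(Cl)cc3)o2)C1O` gives 63 mg/kg, and compound 2 `O=C1CN(/N=C/c2ccc(-c3cccc(C(F)(F)F)c3)o2)C(=O)N1` gives 166 mg/kg. Compound 1 therefore has the lower of the two numbers, meaning that less of it is needed for the effect, and the gap between the two lies beyond the usual scatter. These two compounds differ in more than one place, so their gap cannot be tied to any single change.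

Compound 3 `O=C1NC(=O)N(/N=C/c2ccc(-c3ccc([N+](=O)[O-])cc3)o2)C1O` has not yet been measured. It keeps the core of compound 1 but carries nitro in place of chloro on an aromatic carbon, para to a large group (nitro in place of chloro on an aromatic carbon). For the measured compounds named here, no measured pair differs by one change alone, so the data give no direct guide to this swap, and no step beyond the scatter is expected in either direction. Among the measured compounds, compound 3 lies closest to compound 1, at 63 mg/kg, so that value serves as the anchor. The expected change is a 1.1-fold lower number from compound 1 to compound 3 (0.02 log units; within the scatter). For compound 3 the estimate is 60 mg/kg, with an expected range from 20 mg/kg to 180 mg/kg.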

Compound 3, dose for half-maximal effect: 171 mg/kg
The estimate for compound 3 lay 2.9-fold (0.45 log units) below the measured number; the measured number falls inside the stated range.
By their numbers in this assay, from the lowest: compound 1; then compounds 2 and 3 (each within the scatter of the next).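

For the compounds shown here, with the shared core held fixed, the swap of nitro in place of chloro on an aromatic carbon, para to a large group, gives the first step in this assay that can be tied to one change: a 2.7-fold higher number from compound 1 to compound 3 (0.43 log units; beyond the scatter). The earlier pair differed in more than one place and could not show this, whereas this pair shows that the group at this one position can by itself move the number beyond the scatter, with more compound needed for the effect when nitro sits there than when chloro does. The step is modest and rests on a single pair, and no measurement at hand accounts for it, so the data show its size and direction but not its cause.

One swap cannot show how the number responds across a range of groups at this position, such as fluoro, methoxy, an amine or a carboxylic acid, or whether any of them would need less compound than chloro. Also open, from the compounds shown here alone, is whether nitro in place of chloro would give a step of similar size and direction on a different core.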